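A few compounds are considered here, and "the series" means these few. Any claim that something is new, unique, unknown or untested is made for them only; others in the source may bear on it.

Measured compounds:
compound 1 `O=C(O)CC(Cc1nc2cc(Cl)ccc2[nH]1)c1ccc(Cl)cc1` — 0%
compound 2 `COC(=O)c1ccc2[nH]c(CC(CC(=O)O)c3ccc(Cl)cc3)nc2c1` — 0%

In an assay on isolated protein for inhibition of protein kinase C zeta type (Homo sapiens), read by 33P incorporation, tested at 50 uM (on this read-out lower numbers stand for a weaker effect and higher numbers for a stronger effect at the one concentration tested), compound 1 gives 0%, level with compound 2 at the digits shown. For the measured compounds named here, the one step, no change at the digits printed from compound 1 to compound 2 (within the scatter), changes the other ring and lies within the scatter, so it does not bear on the present change. Compound 3 `O=C(O)CC(Cc1nc2cc(Cl)ccc2[nH]1)c1ccc(Cl)cc1Cl` differs from compound 1 by chloro in place of hydrogen on an aromatic carbon. Going by the values given here, no measured step touches this ring, so the expectation rests only on the flat readings of compound 1 and compound 2, and the step of a number 3 percentage points higher from compound 1 to compound 3 (within the scatter) is expected to stay within the scatter. Compound 3 is therefore estimated at 3% in this assay, range 0% to 20%.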

Compound 3, a percentage reported as inhibition, at one concentration (the size of the read-out at that concentration, not a potency): 30%
Beside the measured number, compound 3's estimate is 27 percentage points below it; measured number above the stated range.
By their numbers in this assay, from the lowest: compounds 1 and 2 (each within the scatter of the next); then compound 3.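

In this assay, the change from 4-chlorophenyl to 2,4-dichlorophenyl gives a number 30 percentage points higher from compound 1 to compound 3 (beyond the scatter), the only step shown that lies beyond the scatter. This places the first measurable response at an aromatic carbon ortho to a large group and meta to a chloro group, on the ring that the earlier step left untouched. No available data explain the rise.

From the compounds shown here alone, whether bromo or methoxy at this place would match chloro remains open. So does whether the rise would hold with methoxycarbonyl in place of chloro on the other ring.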